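The source may hold more compounds than are shown below. What is called first, only, known or untested is meant among the compounds shown, and "the series" means these compounds.

Of the compounds shown here, three built on one shared core have been tested in a functional assay on HCT-116 cells (Homo sapiens) for inhibition, read by sulforhodamine B assay, with a stated time of 48 h; a lower number here means a stronger inhibitor of growth, a higher number a weaker inhibitor of growth. Compound 1 `O=C(Nc1cccc(-n2cc(-c3ccncc3)c(-c3ccc(Cl)c(O)c3)n2)c1)Nc1cccc(C(F)(F)F)c1` gives 8260 nM. Compound 2 `COc1cc(-c2nn(-c3cccc(NC(=O)c4cccc(C(F)(F)F)c4)c3)cc2-c2ccncc2)ccc1Cl` reaches only the limit of the assay, > 50000 nM. Compound 3 `COc1cc(-c2nn(-c3cccc(NC(=O)Nc4ccc(Cl)c(Cl)c4)c3)cc2-c2ccncc2)ccc1Cl` likewise stops at the limit, > 50000 nM. The step that the two limits leave unreadable from compound 2 to compound 3 therefore cannot be read, as both of its values sit at the limit of > 50000 nM in this assay, at which 2 of the 3 values shown sit. Compound 4 `O=C(Nc1cccc(-n2cc(-c3ccncc3)c(-c3ccc(Cl)c(O)c3)n2)c1)Nc1ccc(Cl)c(Cl)c1` differs from compound 3 by hydrogen in place of methyl on an oxygen on an aromatic ring. Going by the values given here, no measured step covers this change; compound 1 and compound 3 differ in two places, so their values show only that compound 1 gives a number where compound 3 gives a limit. Compound 4 is therefore expected to give 15000 nM, within 4000 nM to 50000 nM, an expected step of an at least 3.3-fold lower number from compound 3 to compound 4 (0.52 log units; beyond the scatter) that may still end at a limit.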

Compound 4, concentration for total growth inhibition: 5730 nM
Estimate against measurement, compound 4: 2.6-fold (0.42 log units) above; the range from low to high includes it.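

Changing methoxy to hydroxy on this oxygen turns a limit into a readable number in this assay: an at least 8.7-fold lower number from compound 3 to compound 4 (0.94 log units; beyond the scatter). From the compounds shown here alone, compound 3 gives only a limit, so the full size of that step stays unknown: the limit of > 50000 nM in this assay, at which 2 of the 4 values shown sit. With the hydroxy in place, swapping the 3-(trifluoromethyl)phenyl for 3,4-dichlorophenyl on the amide-type nitrogen makes no difference beyond the scatter: a 1.4-fold lower number from compound 1 to compound 4 (0.16 log units; within the scatter).

The compounds shown leave open how an amine in place of the hydroxy, or a longer chain such as ethyl on this oxygen, would read. They also leave open whether the same change would give a number on the amide of compound 2.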